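This account rests on a few compounds, and the source may have more. Where it says the series, first, only, none or still open, it means among the compounds named here.

Measured compounds in a functional assay on MCF7 cells (Homo sapiens) for cytotoxicity, read by neutral red uptake, with a stated time of 3 days; on this read-out higher numbers stand for weaker inhibition and lower numbers for stronger inhibition:
compound 1 `Nc1ccc(-c2cc(=O)c3c(N)c(F)cc(F)c3o2)cc1F`: 40 nM
compound 2 `C[S+]([O-])c1c(F)c(N)c2c(=O)cc(-c3ccc(N)c(F)c3)oc2c1F`: 2500 nM
compound 3 `CCOC(=O)c1c(F)c(N)c2c(=O)cc(-c3ccc(N)c(F)c3)oc2c1F`: 1400 nM

Compound 3 has the second highest of the three numbers. Compound 2 is nearest, with a number within the scatter of compound 3, and compound 1 is furthest, separated by the step of a 35-fold higher number from compound 1 to compound 3 (1.54 log units; beyond the scatter). Compound 4 `CN(C)CCCC(=O)OCc1c(F)c(N)c2c(=O)cc(-c3ccc(N)c(F)c3)oc2c1F` differs from compound 3 at one aromatic carbon: (((3-(dimethylamino)propyl)carbonyl)oxy)methyl in place of ethoxycarbonyl on an aromatic carbon.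

Two kinds of measured step bear on this change. Replacing hydrogen at this carbon gave a 35-fold higher number from compound 1 to compound 3 (1.54 log units; beyond the scatter) and a 63-fold higher number from compound 1 to compound 2 (1.80 log units; beyond the scatter), both large rises. Exchanging one group for another at the same carbon gave a 1.8-fold lower number from compound 2 to compound 3 (0.25 log units; within the scatter), within the scatter. Compound 4 keeps a group at this position, so the large rise seen from compound 1 is expected to persist, while the exchange of one group for another is expected to produce little change, as between compound 2 and compound 3. For the measured compounds named here, no measured step covers a group as large as the one entering, so the range is set wide. The step of a 1.1-fold higher number from compound 3 to compound 4 (0.03 log units; within the scatter) is therefore expected to stay within the scatter. The expected value for compound 4 in this assay is 1500 nM, with a range from 400 nM to 6000 nM.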

Compound 4, half-maximal inhibitory concentration: 29 nM
Compound 4: middle estimate off by 52-fold (1.71 log units), on the high side, and the stated range ends above it.
By their numbers in this assay, from the lowest: compounds 4 and 1 (each within the scatter of the next); then compounds 3 and 2 (each within the scatter of the next).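

In this assay, a group on this aromatic carbon, ortho to two fluoro groups, does not by itself go with a weak number: (((3-(dimethylamino)propyl)carbonyl)oxy)methyl gives a 48-fold lower number from compound 3 to compound 4 (1.68 log units; beyond the scatter) and an 86-fold lower number from compound 2 to compound 4 (1.94 log units; beyond the scatter) as well. Set against the hydrogen of compound 1, the same group gives a 1.4-fold lower number from compound 1 to compound 4 (0.14 log units; within the scatter) and so leaves the number within the scatter, whereas a 35-fold higher number from compound 1 to compound 3 (1.54 log units; beyond the scatter) and a 63-fold higher number from compound 1 to compound 2 (1.80 log units; beyond the scatter) are both large rises. The outcome at this carbon therefore depends on which group is attached, a much larger group being tolerated here while two smaller ones are not, and no measurement at hand accounts for the difference.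

Compound 4 differs from compound 3 in its link to the ring, its chain and its terminal dimethylamino group all at once, so the compounds shown do not tell which of these parts goes with the large drop. A hydroxymethyl group, a carboxylic acid, or the same ester chain ending in a morpholine would help to separate these parts at this carbon.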